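Benzyl in place of isopropyl: compound 2 to compound 4

The source may hold more compounds than are shown below. What is called first, only, known or untested is meant among the compounds shown, and "the series" means these compounds.

In a functional assay on T98G cells (Homo sapiens) for inhibition, read by MTT assay, with a stated time of 72 h (on this read-out lower numbers stand for stronger inhibition and higher numbers for weaker inhibition), compound 1 (`CC1(C)CC(NC(=S)NCc2ccccc2)c2cc(F)ccc2O1`) gives 40000 nM and compound 2 (`CC(C)NC(=S)NC1CC(C)(C)Oc2ccc(Cl)cc21`) gives 91000 nM as measured. Compound 3 (`CCNC(=O)NC1CC(C)(C)Oc2ccc(Cl)cc21`) carries the entry "not determined" (no result reported) and adds no number. Compound 2 therefore stands highest of the two numbers available, and compound 1 lies lower by a gap beyond the usual scatter.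

Compound 4 (`CC1(C)CC(NC(=S)NCc2ccccc2)c2cc(Cl)ccc2O1`) is still unmeasured. The change from compound 2 is benzyl in place of isopropyl on an amide-type nitrogen with benzyl in place of isopropyl on an amide-type nitrogen. Among the compounds with values here, no measured pair isolates this change, so the evidence is indirect. In this assay compound 1, which also holds the benzyl group, gives 40000 nM and that value is the reason to expect a lower number for compound 4. The expected step of a 2.4-fold lower number from compound 2 to compound 4 (0.38 log units; beyond the scatter) in this assay is a modest fall, only just beyond the scatter. The estimate for compound 4 is 38000 nM with an expected range from 15000 nM to 90000 nM as the likely span.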

Compound 4, half-maximal inhibitory concentration: 99000 nM
Compound 4: the middle estimate sits 2.6-fold (0.42 log units) below what was measured, outside the stated range (above it).
By their numbers in this assay, from the lowest: compound 1; then compounds 2 and 4 (each within the scatter of the next).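

In this assay benzyl in place of isopropyl on the amide-type nitrogen gives a 1.1-fold higher number from compound 2 to compound 4 (0.04 log units; within the scatter) and so, with chloro on the aromatic carbon, the two groups cannot be told apart at this position. Benzyl alone therefore does not account for the lower number of compound 1, since chloro in place of fluoro on the aromatic carbon gives a 2.5-fold higher number from compound 1 to compound 4 (0.39 log units; beyond the scatter) and this modest step is what separates the two benzyl compounds. No measurement shown here bears on the reason for either step.

On these data alone, whether fluoro in place of chloro gives a similar step with isopropyl on the nitrogen remains open. Also open, as far as these compounds go, is how a methoxy group on that aromatic carbon, or an aminoethyl chain on the amide-type nitrogen, would read.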